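The source may hold more compounds than are shown below. What is called first, only, known or untested is meant among the compounds shown, and "the series" means these compounds.

Measured compounds:
- Compound 1, `Cc1ccc2[nH]c(-n3[nH]c(C)c(Cc4ccccc4)c3=O)nc2c1`: 670 nM
- Compound 2, `Cc1cc(O)n(-c2nc3ccccc3[nH]2)n1`: 3600 nM
- Compound 3, `Cc1[nH]n(-c2nc3cc(C(C)(C)C)ccc3[nH]2)c(=O)c1Cc1ccccc1`: 640 nM

In an assay on isolated protein for inhibition of alpha-ketoglutarate-dependent dioxygenase alkB homolog 3 (Homo sapiens), read by polymerase chain reaction, with a stated time of 1 h (on this read-out lower numbers stand for stronger inhibition and higher numbers for weaker inhibition), compound 3 gives the lowest number of the three, though compound 1 sits within the scatter of it, and only compound 2 stands clearly apart with a higher number. Compound 4, `Cc1[nH]n(-c2nc3cc(-c4ccc(Cl)cc4)ccc3[nH]2)c(=O)c1Cc1ccccc1`, has not been measured. It differs from compound 3 by 4-chlorophenyl in place of tert-butyl on an aromatic carbon. Going by the values given here, the one measured step at this position, a 1.0-fold lower number from compound 1 to compound 3 (0.02 log units; within the scatter), stayed within the scatter, so enlarging the group there has so far made no clear difference. Among the compounds with values here, no measured pair shows an aromatic ring entering at this place, so the expected step of a 1.3-fold lower number from compound 3 to compound 4 (0.11 log units; within the scatter) is small with a wide margin. Compound 4 is therefore estimated at 500 nM, in a range from 120 nM to 2500 nM.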

Compound 4, half-maximal inhibitory concentration: 1500 nM
Compound 4: middle estimate off by 3.0-fold (0.48 log units), on the low side; measured number inside the range.
By their numbers in this assay, from the lowest: compounds 3 and 1 (each within the scatter of the next); then compound 4; then compound 2.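

Replacing methyl with tert-butyl left the number within the scatter, but an aromatic ring at this place does shift it, bringing a 2.3-fold higher number from compound 3 to compound 4 (0.37 log units; beyond the scatter) and a 2.2-fold higher number from compound 1 to compound 4 (0.35 log units; beyond the scatter) as modest steps. So this position does not treat all larger groups alike, at least across these three compounds. Nothing available here explains the shift.

A single ring compound cannot separate the part played by the ring from that of the chlorine. Plain phenyl, a pyridine ring or an amine at this place would help to settle what the position accepts.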